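Swapping a methoxy for a chloro on the pyrazolone aryl

The source may report more compounds than this note shows. Statements on the series, on what has been measured and on what is new or still open speak of the compounds shown alone.

Of the compounds shown here, two have been measured so far. In a functional assay on NCI-H460 cells (Homo sapiens) for inhibition, read by MTT assay, with a stated time of 72 h (a higher number here means a weaker inhibitor, a lower number a stronger inhibitor), compound 1 `COc1cc2c(Oc3ccc(NC(=O)c4nn(-c5ccccc5OC(F)(F)F)c(=O)cc4C)cc3F)ccnc2cc1OCCCN1CCCC1` gives 210 nM, while compound 2 `COc1ccc(-n2nc(C(=O)Nc3ccc(Oc4ccnc5cc(OCCCN6CCCC6)c(OC)cc45)c(F)c3)c(C)cc2=O)cc1` gives 3610 nM. Compound 2 therefore has the highest number of the two, and the step of a 17-fold higher number from compound 1 to compound 2 (1.24 log units; beyond the scatter) shows that the aryl group on the aromatic nitrogen of the shared core can move the result a long way.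

Compound 3 `COc1cc2c(Oc3ccc(NC(=O)c4nn(-c5ccc(Cl)cc5)c(=O)cc4C)cc3F)ccnc2cc1OCCCN1CCCC1` is a close relative of compound 2, differing by chloro in place of methoxy on an aromatic carbon. Among the measured compounds shown here, the only measured step that bears on this is the one from compound 1 to compound 2, which was large, but it changed both the group and its position, so it does not directly say how chloro compares with methoxy at the same place. Given that compound 2 sits at the weak end of the two numbers, a modest recovery is expected for compound 3, and the step of a 2.4-fold lower number from compound 2 to compound 3 (0.38 log units; beyond the scatter) is the estimated change. Compound 3 is thus expected to give about 1500 nM in this assay, most likely between 400 nM and 5000 nM.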

Compound 3, half-maximal inhibitory concentration: 360 nM
Compound 3: middle estimate off by 4.2-fold (0.62 log units), on the high side, outside the stated range (below it).
By their numbers in this assay, from the lowest: compounds 1 and 3 (each within the scatter of the next); then compound 2.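

On the aromatic carbon para to a large group, replacing methoxy with chloro changes nothing else in the molecule, yet it gives a 10-fold lower number from compound 2 to compound 3 (1.00 log units; beyond the scatter) in this assay. This shows that a single substituent at this one place can shift the result by a large amount, something the earlier step could not show, since it changed both the group and its position. The other comparison gives a 1.7-fold higher number from compound 1 to compound 3 (0.23 log units; within the scatter), so this assay does not separate the 4-chlorophenyl and 2-(trifluoromethoxy)phenyl groups, and the weak result of compound 2 stands apart from both; nothing available goes beyond these numbers to explain the difference.

Going by these compounds, with only methoxy and chloro compared at this place, it remains open whether methoxy lowers activity or chloro raises it, and how a nitrile or a dimethylamino group on the same carbon would read. A 4-(trifluoromethoxy)phenyl group would help show how much depends on the group itself and how much on where it sits on the ring.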